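This account rests on a few compounds, and the source may have more. Where it says the series, first, only, none or still open, it means among the compounds named here.

The set comprises compound 1 `Cc1cn([C@H]2C[C@H](SSc3ccc([N+](=O)[O-])cc3)[C@@H](CO)O2)c(=O)[nH]c1=O`, compound 2 `CCCCSS[C@H]1C[C@H](n2cc(C)c(=O)[nH]c2=O)O[C@@H]1CO`, compound 3 `Cc1cn([C@H]2C[C@H](SSCCN)[C@@H](CO)O2)c(=O)[nH]c1=O` and, still to be measured, compound 4 `Cc1cn([C@H]2C[C@H](SSCCCCCCO)[C@@H](CO)O2)c(=O)[nH]c1=O`. In a physicochemical assay for pharmacokinetics, at pH 7.2 (a higher number here means that the compound lasts longer, a lower number that the compound disappears faster), compound 1 gives only a limit, < 0.0834 h. In this assay compound 2 likewise gives a limit, < 0.0834 h. Compound 3 stands at the same limit, < 0.0834 h, so no number is known for it. All three values sit at the limit of < 0.0834 h in this assay, at which 3 of the 3 values shown sit. The steps between them are therefore a step that the two limits leave unreadable from compound 1 to compound 2, a step that the two limits leave unreadable from compound 1 to compound 3 and a step that the two limits leave unreadable from compound 2 to compound 3; none of them has a readable size.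

Compound 4 differs from compound 3 by 4-hydroxybutyl in place of amino on a saturated chain carbon, two bonds along the chain from a sulfur. Going by the values given here, no measured step bears on this change with a readable size, and every measured compound sits at the limit. He therefore expects the step that the limit leaves unreadable from compound 3 to compound 4 to lead compound 4 to a half-life that also falls at or near the limit, estimated at 0.05 h, between 0.01 h and 0.3 h, most likely reported again only as a limit.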

Compound 4, half-life: < 0.0834 h
Compound 4 gave a limit, no number (the forecaster's own chance of this, stated with the estimate: 80%); the middle value is on the limit's open side.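

No step between compound 4 and compound 1, compound 2 or compound 3 can be read in this assay, since all four compounds end at a limit and give no number: the limit of < 0.0834 h in this assay, at which 4 of the 4 values shown sit.

The compounds shown leave open what any actual half-life is, and whether the group on the sulfur makes any difference to it.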